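The source may hold more compounds than are shown below. What is called first, only, known or untested is meant among the compounds shown, and "the series" means these compounds.

Compound 1 `CN1C(=O)C(c2ccccc2)N(C)c2nc(Nc3ccc(S(N)(=O)=O)cc3)ncc21` gives 383 nM in an assay on Sf9 cells for inhibition of serine/threonine-protein kinase 4 (Homo sapiens), read by luminescence and ADP-Glo, with a stated time of 1 h, in the presence of a further agent that is not named here (a higher number here means a weaker inhibitor, a lower number a stronger inhibitor), the highest of the three numbers recorded. Compound 2 `CCc1ccccc1C1C(=O)N(C)c2cnc(Nc3ccc(S(N)(=O)=O)cc3)nc2N1C` gives 51 nM in this assay, and compound 3 `CN1C(=O)C(c2ccccc2Br)N(C)c2nc(Nc3ccc(S(N)(=O)=O)cc3)ncc21` gives 57 nM. The change to compound 4 `CN1C(=O)C(c2c(F)cccc2F)N(C)c2nc(Nc3ccc(S(N)(=O)=O)cc3)ncc21` is 2,6-difluorophenyl in place of phenyl on a saturated ring carbon. For the measured compounds named here, two measured steps bear on it, each placing a group on an aromatic carbon of the same phenyl: a 7.5-fold lower number from compound 1 to compound 2 (0.88 log units; beyond the scatter) and a 6.7-fold lower number from compound 1 to compound 3 (0.83 log units; beyond the scatter), while a 1.1-fold higher number from compound 2 to compound 3 (0.05 log units; within the scatter) shows that ethyl and bromo gave much the same outcome. Two fluorines entering that ring are therefore expected to lower the number beyond the scatter, though likely by less than ethyl or bromo did. Compound 4 is estimated at 100 nM (range 35 nM to 280 nM), an expected step of a 3.8-fold lower number from compound 1 to compound 4 (0.58 log units; beyond the scatter).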

Compound 4, half-maximal inhibitory concentration: 42 nM
Beside the measured number, compound 4's estimate is 2.4-fold (0.38 log units) above it, and the stated range covers the measured number.
By their numbers in this assay, from the lowest: compounds 4, 2 and 3 (each within the scatter of the next); then compound 1.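

The 2,6-difluorophenyl group matches the gain seen with the other two substituted rings: in this assay the change gives a 9.1-fold lower number from compound 1 to compound 4 (0.96 log units; beyond the scatter), while a 1.4-fold lower number from compound 3 to compound 4 (0.13 log units; within the scatter) and a 1.2-fold lower number from compound 2 to compound 4 (0.08 log units; within the scatter) leave compound 4 within the scatter of both. At this position, then, three different substituted phenyl groups all improve on the unsubstituted phenyl and cannot be told apart from one another. Nothing available explains why these substituents give such similar numbers.

As far as these compounds go, it remains open whether a single fluorine on the ring would do as much. From the compounds shown here alone, it is also open whether a methoxy group or an amine there would give a similar number.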